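The compounds below may be only part of what the source reports. "The series", "measured", "known", "first", "only" and "open" are said of these compounds alone.

In a functional assay on MCF7 cells (Homo sapiens) for antiproliferative activity, read by MTT assay, with a stated time of 72 h (a higher number here means a weaker inhibitor, a lower number a stronger inhibitor), compound 1 `COc1cc2c(Nc3ccc(C#N)cc3)ncnc2cc1OCCCN(C)C` gives 45000 nM. Compound 2 `CCN(CC)CCCOc1cc2ncnc(Nc3ccc(C#N)cc3)c2cc1OC` gives > 100000 nM, which is a limit and not a number. Compound 3 `COc1cc2c(Nc3ccc(C#N)cc3)ncnc2cc1OCCCN1CCCCC1CCO` gives > 100000 nM, again a limit and not a number. Changing the amine on the chain gave an at least 2.2-fold higher number from compound 1 to compound 2 (0.34 log units; beyond the scatter), an at least 2.2-fold higher number from compound 1 to compound 3 (0.34 log units; beyond the scatter) and a step that the two limits leave unreadable from compound 2 to compound 3. Compound 4 `COc1cc2c(Nc3ccc(C#N)cc3)ncnc2cc1OCCCN1CCC(N2CCCCC2)CC1` has 4-(piperidin-1-yl)piperidin-1-yl in place of 2-(2-hydroxyethyl)piperidin-1-yl (4-(piperidin-1-yl)piperidin-1-yl in place of 2-(2-hydroxyethyl)piperidin-1-yl on a saturated chain carbon, three bonds along the chain from an oxygen on an aromatic ring). This is another swap of the same amine, so compound 4 is expected to stay weak, like compound 3 with > 100000 nM, and may also reach the limit. The expected change is small, towards a lower number if any: an at least 1.2-fold lower number from compound 3 to compound 4 (0.09 log units; that floor lies within the scatter). For compound 4 the estimated value is 80000 nM, within a range of 30000 nM to 200000 nM.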

Compound 4, half-maximal inhibitory concentration: 19600 nM
The estimate for compound 4 lay 4.1-fold (0.61 log units) above the measured number; measured number outside the range, below it.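

Changing the amine at this place on the chain can also lower the number: 4-(piperidin-1-yl)piperidin-1-yl gives an at least 5.1-fold lower number from compound 3 to compound 4 (0.70 log units; beyond the scatter) and an at least 5.1-fold lower number from compound 2 to compound 4 (0.70 log units; beyond the scatter) in the two comparisons with the weakest compounds. It also gives a 2.3-fold lower number from compound 1 to compound 4 (0.36 log units; beyond the scatter) so compound 4 is the strongest of the four. The first two steps are only floors, set by a limit and not by a number: the limit of > 100000 nM in this assay, at which 2 of the 4 values shown sit.

The compounds shown leave open whether the second ring or the second nitrogen goes with the lower number. A plain piperidin-1-yl group and a 4-(dimethylamino)piperidin-1-yl group on the same chain would help separate the two.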